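Dropping one chloro from a dichlorophenyl chalcone

A few compounds are considered here, and "the series" means these few. Any claim that something is new, unique, unknown or untested is made for them only; others in the source may bear on it.

Compound 1, `COc1ccc(-c2nn(-c3ccccc3)cc2/C=C/C(=O)c2ccc(OCc3ccccc3)c3c2OC(C)(C)C3)cc1`, in a functional assay on PC-3 cells (Homo sapiens) for antiproliferative activity, read by MTT assay, with a stated time of 48 h; on this read-out lower numbers stand for stronger inhibition and higher numbers for weaker inhibition: compound 1 gives 7900 nM.
Compound 2, `CC1(C)Cc2c(OCc3ccccc3)ccc(C(=O)/C=C/c3cn(-c4ccccc4)nc3-c3cccc([N+](=O)[O-])c3)c2O1`: compound 2 gives 5900 nM.
Compound 3, `CC1(C)Cc2c(OCc3ccccc3)ccc(C(=O)/C=C/c3ccc(Cl)cc3Cl)c2O1`: for compound 3 only a limit is known, > 100000 nM.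

The three measured compounds share the same core and differ in the aryl group attached to the ethenyl. Among the measured compounds shown here, compound 1 and compound 2 carry a substituted pyrazole there, and the one measured step between them, a 1.3-fold lower number from compound 1 to compound 2 (0.13 log units; within the scatter), concerns a 3-nitrophenyl in place of 4-methoxyphenyl on that pyrazole. Compound 3 carries a 2,4-dichlorophenyl instead and sits at the limit of this assay, as noted in the limit of > 100000 nM in this assay, at which 1 of the 3 values shown sits.

Compound 4, `CC1(C)Cc2c(OCc3ccccc3)ccc(C(=O)/C=C/c3ccc(Cl)cc3)c2O1`, differs from compound 3 in one place: hydrogen in place of chloro on an aromatic carbon. For the measured compounds named here, no measured step among the three compounds touches this position or this kind of change, so the only guide is where compound 3 itself stands. The writer therefore expects the step of an at least 1.2-fold lower number from compound 3 to compound 4 (0.09 log units; that floor lies within the scatter) to be small and not clearly beyond the scatter, with a real chance that this assay again reports only a limit. Compound 4 is accordingly estimated at 80000 nM, with a range from 20000 nM to 300000 nM.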

Compound 4, half-maximal inhibitory concentration: > 100000 nM
Compound 4 ended at the assay's limit (the forecaster's own chance of this, stated with the estimate: 55%); at least 1.2-fold (0.09 log units) between middle value and limit.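

In this assay compound 4 is reported only as a limit, > 100000 nM. Compound 3 is likewise only a limit, > 100000 nM. No step between compound 3 and compound 4 can therefore be read: the limit of > 100000 nM in this assay, at which 2 of the 4 values shown sit.

The compounds shown leave open whether hydrogen in place of chloro on this aromatic ring changes antiproliferative activity at all.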